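Chloro to Trifluoromethyl Beside a Methylsulfanyl Group

The source may report more compounds than this note shows. Statements on the series, on what has been measured and on what is new or still open speak of the compounds shown alone.

Compound 1, `COc1ccc(SC)c(NCC2=NCCN2)c1`, and compound 2, `CSc1ccc(Cl)cc1NCC1=NCCN1`, share one core and differ at a single aromatic carbon, where a methoxy group in compound 1 is replaced by chloro in compound 2. In an assay on CHO cells for binding affinity to Alpha-2B adrenergic receptor (Homo sapiens), read by radioligand binding (a higher number here means a weaker inhibitor, a lower number a stronger inhibitor), compound 1 gives only a limit, < 6310 nM, and not a number. In this assay, among the compounds with values here, compound 2 gives 676 nM, which is the only number among the values shown. The change a step that the limit leaves unreadable from compound 1 to compound 2 cannot be given a size because the limit of < 6310 nM in this assay, at which 1 of the 2 values shown sits, hides where compound 1 truly sits.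

Compound 3, `CSc1ccc(C(F)(F)F)cc1NCC1=NCCN1`, has not been measured yet. It differs from compound 2 by trifluoromethyl in place of chloro on an aromatic carbon. Within the data shown here, no measured step speaks to this exchange: the single measured step concerns a different group and is itself unreadable. With nothing to point either way, the expected step is a 1.2-fold higher number from compound 2 to compound 3 (0.07 log units; within the scatter), none beyond the usual scatter, but with a wide margin of doubt. Compound 3 is therefore estimated to give about 800 nM in this assay, with a range from 150 nM to 4000 nM.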

Compound 3, inhibition constant: 1660 nM
Compound 3: middle estimate off by 2.1-fold (0.32 log units), on the low side, and the stated range covers the measured number.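

In this assay, placing trifluoromethyl instead of chloro on the aromatic carbon para to the methylsulfanyl group gives a 2.5-fold higher number from compound 2 to compound 3 (0.39 log units; beyond the scatter). Within the data shown here, this is the first step at this position with a readable size, and it shows that the two groups are not interchangeable here: compound 2, with chloro, is the stronger inhibitor of this pair, although the difference is modest. The steps from compound 1, which carries methoxy at this position, to compound 2 and to compound 3 cannot be read because compound 1 has a limit and not a number: the limit of < 6310 nM in this assay, at which 1 of the 3 values shown sits.

A single readable step cannot show whether the change in binding follows from the number of heavy atoms in the group, since chloro and trifluoromethyl differ in more than that count. From the compounds shown here alone, how fluoro, a nitrile or an amine would compare with chloro on this aromatic carbon remains open, as does whether the exchange of chloro for trifluoromethyl would give a similar step if the methylsulfanyl group were replaced by a longer chain.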